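Inverting a ring stereocentre in a sulfonamide benzamide

The source may hold more compounds than are shown below. What is called first, only, known or untested is meant among the compounds shown, and "the series" means these compounds.

Compound 1, `CCCCN1CCC[C@@H]1CNC(=O)c1cc(S(N)(=O)=O)ccc1OC`: 92.3 mg/kg
Compound 2, `CCCCCCN1CCC[C@H]1CNC(=O)c1cc(S(N)(=O)=O)ccc1OC`: only a limit, > 100 mg/kg

In a functional assay on the whole organism with Mus musculus as the target (a lower number here means that less compound is needed, a higher number that more compound is needed for the effect), compound 1 gives 92.3 mg/kg. For compound 2 the same assay reports no number but a limit, > 100 mg/kg. Where compound 2 stands is therefore described only by the limit of > 100 mg/kg in this assay, at which 1 of the 2 values shown sits, so its true value is unknown beyond that boundary.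

Compound 3, `CCCCCCN1CCC[C@@H]1CNC(=O)c1cc(S(N)(=O)=O)ccc1OC`, differs from compound 2 in one respect: the two compounds have the same atoms and bonds and differ only in configuration as drawn: 1 of 1 stereo elements differ; a stereocentre at a saturated ring carbon is drawn S in compound 2 and R in compound 3. Among the measured compounds shown here, no measured pair in this set shows what such an inversion does, so the step has to be judged from the two values alone. Compound 1 shares the drawn configuration of compound 3 and differs from it only in chain length, and its value sits close to the limit that compound 2 reaches. The step from compound 2 to compound 3 is expected to be a step that the limit leaves unreadable from compound 2 to compound 3, with no clear direction beyond the scatter. For compound 3 the expected value is 110 mg/kg, between 40 mg/kg and 300 mg/kg.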

Compound 3, dose for half-maximal effect: 28.2 mg/kg
Compound 3: middle estimate off by 3.9-fold (0.59 log units), on the high side; the measured number lies below the stated range.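

In this assay, turning the stereocentre at the saturated ring carbon from S to R gives an at least 3.5-fold lower number from compound 2 to compound 3 (0.54 log units; beyond the scatter), and this step can be assigned to the configuration alone: the fact that compounds 2 and 3 differ only in the configuration as drawn

From the compounds shown here alone, compound 2 has only a limit, > 100 mg/kg, so the true size of this step remains unknown.

With the R configuration kept, ethyl in place of hydrogen on a saturated chain carbon, four bonds along the chain from an amine nitrogen in a ring, gives a 3.3-fold lower number from compound 1 to compound 3 (0.51 log units; beyond the scatter), so the chain matters here as well as the stereocentre.

The compounds shown leave open whether the same inversion has a similar effect with the shorter chain of compound 1. They also leave open whether a longer chain, such as octyl, or a benzyl group on the amine nitrogen in the ring would lower the number further.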